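The source may report more compounds than this note shows. Statements on the series, on what has been measured and on what is new or still open speak of the compounds shown alone.

Working notes, thiosemicarbazone series. Compound 1 `N/C(=N\NC(=S)N1CCOCC1)c1ccccn1` gives 66.7% in a functional assay on MCF7 cells (Homo sapiens) for cytotoxicity, read by MTT assay, with a stated time of 72 h, tested at 10 uM; a lower number here means less inhibition of growth, a higher number more inhibition of growth at the concentration tested. Compound 2 `N/C(=N\NC(=S)N1CCCC1)c1ccc(F)cn1`, which carries a fluorine on the pyridine, gives 54.5% in this assay. Compound 3 `N/C(=N\NC(=S)N1CCSCC1)c1ccc(F)cn1` gives 38.1% in this assay, the lowest of the three numbers; the nearest is compound 2, the furthest compound 1, both gaps beyond the scatter.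

Compound 4 `N/C(=N\NC(=S)N1CCOCC1)c1ccc(F)cn1` is not yet measured. Relative to compound 3 the change is morpholin-4-yl in place of thiomorpholin-4-yl on a thiocarbonyl carbon. For the measured compounds named here, the only measured single step, a number 16.4 percentage points lower from compound 2 to compound 3 (beyond the scatter), shows that the ring on the thiocarbonyl carbon moves the number by a modest amount. Compound 1 and compound 3 differ in two places, so their gap cannot be assigned to the ring alone; still, the morpholine-bearing compound 1 stands highest of the three. On that basis compound 4 is expected to lie above compound 3, with the step of a number 15.9 percentage points higher from compound 3 to compound 4 (beyond the scatter) estimated as modest and upward. The estimate for compound 4 in this assay is 54%, expected to fall between 40% and 68%.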

Compound 4, percent growth inhibition at one concentration: 39.5%
For compound 4 the middle estimate is 14.5 percentage points above the measured one; measured number outside the range, below it.
By their numbers in this assay, from the lowest: compounds 3 and 4 (each within the scatter of the next); then compound 2; then compound 1.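

On the thiocarbonyl carbon, morpholin-4-yl in place of thiomorpholin-4-yl gives a number 1.4 percentage points higher from compound 3 to compound 4 (within the scatter) in this assay and so does not separate these two six-membered rings, whereas pyrrolidin-1-yl stands apart from both, with a number 16.4 percentage points lower from compound 2 to compound 3 (beyond the scatter) and a number 15 percentage points lower from compound 2 to compound 4 (beyond the scatter) on the same fluorinated core. For the compounds shown here, with morpholin-4-yl held constant, fluoro in place of hydrogen on an aromatic carbon gives a number 27.2 percentage points lower from compound 1 to compound 4 (beyond the scatter), a first single-change reading of this exchange, which places the high number of compound 1 with the hydrogen-bearing core in this pair. Nothing measured here bears on why these steps take their size.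

On these data alone, whether the fluoro step has a similar size with pyrrolidin-1-yl or thiomorpholin-4-yl on the thiocarbonyl carbon remains open. As far as these compounds go, how a piperazin-1-yl ring or an open-chain dimethylamino group would stand at this position is also open.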